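The source may report more compounds than this note shows. Statements on the series, on what has been measured and on what is new or still open speak of the compounds shown alone.

Measured so far in a functional assay on DU-145 cells (Homo sapiens) for antiproliferative activity, read by MTT assay, with a stated time of 24 h; a lower number here means a stronger inhibitor, a higher number a weaker inhibitor:
Compound 1 `COc1ccc(-c2noc(-c3ccccc3)n2)cc1OC1CCCC1`: > 1000000 nM, a limit.
Compound 2 `COc1ccc(-c2noc(-c3ccncc3)n2)cc1OC1CCCC1`: > 1000000 nM, a limit.
Compound 3 `COc1ccc(-c2noc(-c3ccc(O)cc3)n2)cc1OC1CCCC1`: 780 nM.

Compound 3 alone has a true number, 780 nM. The other two results are not numbers: they are the limit of > 1000000 nM in this assay, at which 2 of the 3 values shown sit.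

Compound 4 `COc1ccc(-c2noc(-c3ccc(Cl)cc3)n2)cc1OC1CCCC1` has chloro in place of hydroxy on an aromatic carbon, para to a large group, so that 4-hydroxyphenyl becomes 4-chlorophenyl: chloro in place of hydroxy on an aromatic carbon.

The closest evidence is an at least 1200-fold lower number from compound 1 to compound 3 (3.10 log units; beyond the scatter), which is hydroxy in place of hydrogen at this same place. The change of 4-hydroxyphenyl for pyridin-4-yl points the same way, with an at least 1200-fold lower number from compound 2 to compound 3 (3.10 log units; beyond the scatter). By contrast, a step that the two limits leave unreadable from compound 1 to compound 2 adds nothing. Going by the values given here, no chloro compound has been measured, so the size remains uncertain, but a large move towards a higher number is expected in this assay. The expected change is a 64-fold higher number from compound 3 to compound 4 (1.81 log units; beyond the scatter). For compound 4 the estimate is 50000 nM, with an expected range of 2000 nM to 1000000 nM.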

Compound 4, half-maximal inhibitory concentration: 123000 nM
Estimate against measurement, compound 4: 2.5-fold (0.39 log units) below; low and high end bracket the measured number.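

In this assay, chloro does not stand in for hydroxy at this place on the six-membered aromatic ring, with a 160-fold higher number from compound 3 to compound 4 (2.20 log units; beyond the scatter). Chloro nevertheless differs from hydrogen here, with an at least 8.1-fold lower number from compound 1 to compound 4 (0.91 log units; beyond the scatter), so the hydroxy group of compound 3 is not the only substituent at this place that brings a measurable number, and compound 4 also compares with the pyridin-4-yl compound, with an at least 8.1-fold lower number from compound 2 to compound 4 (0.91 log units; beyond the scatter). Those last two steps give only a lowest size, not a true one, because compounds 1 and 2 each stand at a limit rather than a number: the limit of > 1000000 nM in this assay, at which 2 of the 4 values shown sit.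

The compounds shown leave open whether an amine, a methoxy group or a carboxylic acid at this place would come nearer to hydroxy or to chloro. They also leave open what fluoro or methyl would give there.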